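Swapping Methoxy for Sec-Butyl on the Amide Nitrogen

The source may report more compounds than this note shows. Statements on the series, on what has been measured and on what is new or still open speak of the compounds shown alone.

Three measured compounds share one core and differ only in the group carried on the amide-type nitrogen. In an assay on HEK293 cells for agonist activity at transient receptor potential cation channel subfamily M member 8 (Homo sapiens), read by fluorescence and calcium flux, with a stated time of 15 min (a higher number here means that more compound is needed for the effect, a lower number that less compound is needed), compound 1 `CCN(Cc1cccs1)C(=O)COc1ccc(C)cc1` gives 8 nM. Compound 2 `Cc1ccc(OCC(=O)N(Cc2cccs2)c2ncco2)cc1` gives 0.3 nM in this assay, and compound 3 `CON(Cc1cccs1)C(=O)COc1ccc(C)cc1` gives 10 nM. Compound 3 thus has the highest number of the three, though the gap to compound 1 is small, a 1.3-fold higher number from compound 1 to compound 3 (0.10 log units; within the scatter), and lies within the scatter. The gap to compound 2 is large, a 33-fold higher number from compound 2 to compound 3 (1.52 log units; beyond the scatter).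

Compound 4 `CCC(C)N(Cc1cccs1)C(=O)COc1ccc(C)cc1` has not been measured. Its change from compound 3 is sec-butyl in place of methoxy on an amide-type nitrogen. Among the measured compounds shown here, the one step that bears on this exchange is a 1.3-fold higher number from compound 1 to compound 3 (0.10 log units; within the scatter), which shows that trading a short carbon chain for methoxy on this nitrogen changed little. The reverse exchange, now with a branched sec-butyl chain, gives no reason to expect more than a small shift. The expected step is therefore modest, a 1.3-fold lower number from compound 3 to compound 4 (0.10 log units; within the scatter). Compound 4 is expected to give 8 nM in this assay, with a likely range from 2 nM to 40 nM. For the measured compounds named here, no measured step covers sec-butyl itself, so the range is kept wide.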

Compound 4, half-maximal effective concentration: 2000 nM
Compound 4: middle estimate off by 250-fold (2.40 log units), on the low side; measured number outside the range, above it.
By their numbers in this assay, from the lowest: compound 2; then compounds 1 and 3 (each within the scatter of the next); then compound 4.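

On this amide-type nitrogen, the size and shape of the group matter far more than compounds 1 and 3 suggested: in this assay, sec-butyl in place of methoxy gives a 200-fold higher number from compound 3 to compound 4 (2.30 log units; beyond the scatter), while adding ethyl in place of a hydrogen on the saturated chain carbon gives a 250-fold higher number from compound 1 to compound 4 (2.40 log units; beyond the scatter). Measured against the 1,3-oxazol-2-yl group, the step reaches a 6700-fold higher number from compound 2 to compound 4 (3.82 log units; beyond the scatter), so ethyl and methoxy, which lie within the scatter of each other, did not reveal the steep rise that sec-butyl brings. Nothing measured here explains this rise.

The compounds shown leave open where between ethyl and sec-butyl the rise sets in. An isopropyl group and an unbranched n-propyl or n-butyl chain on this nitrogen would help separate the effect of branching from that of chain length.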